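A new group on the carbonyl of compound 2

The source may report more compounds than this note shows. Statements on the series, on what has been measured and on what is new or still open speak of the compounds shown alone.

In a functional assay on ASPC1 cells (Homo sapiens) for antiproliferative activity, read by MTT assay, with a stated time of 72 h (on this read-out higher numbers stand for weaker inhibition and lower numbers for stronger inhibition), compound 1 `C=CC(=O)Nc1cc(Nc2nccc(NC(=O)c3cccc4ccccc34)n2)c(OC)cc1N1CCN(C)CC1` gives 6600 nM. Compound 2 `C=CC(=O)Nc1cc(Nc2nccc(NC(=O)c3cccc(OC)c3)n2)c(OC)cc1N1CCN(C)CC1` stands only at a limit, > 10000 nM, and has no exact number. Compound 3 `C=CC(=O)Nc1cc(Nc2nccc(NC(=O)c3ccc(C(F)(F)F)cc3)n2)c(OC)cc1N1CCN(C)CC1` keeps the shared core of compound 2 but carries 4-(trifluoromethyl)phenyl in place of 3-methoxyphenyl on a carbonyl carbon, a change counted as 4-(trifluoromethyl)phenyl in place of 3-methoxyphenyl on a carbonyl carbon. Within the data shown here, the only measured step that bears on this change is an at least 1.5-fold higher number from compound 1 to compound 2 (0.18 log units; that floor lies within the scatter), made on the same carbonyl carbon. That step is a floor and not a full size, so it supports no expected step beyond the scatter in this assay, and a second result reported only as a limit would be no surprise. The estimated step is a number no higher from compound 2 to compound 3 (the limit leaves the size open). Compound 3 is expected near 10000 nM, with an estimated range from 4000 nM to 25000 nM.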

Compound 3, half-maximal inhibitory concentration: > 10000 nM
Compound 3 was reported as a limit; the forecaster's own chance of this, stated with the estimate: 55%; the middle value lies on the limit itself.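

With compound 3, a second phenyl group on this carbonyl carbon, 4-(trifluoromethyl)phenyl, also ends at a limit rather than at an exact number, so compound 2 is no longer the only such case. As far as these compounds go, putting this group in place of naphthalen-1-yl gives an at least 1.5-fold higher number from compound 1 to compound 3 (0.18 log units; that floor lies within the scatter), so what can be read of this change does not go beyond the scatter, although its true size stays unknown. The step between compound 2 and compound 3 cannot be read, and the two groups cannot be ranked, because both compounds sit at the same limit: the limit of > 10000 nM in this assay, at which 2 of the 3 values shown sit.

Among these compounds, compound 1 remains the only compound here with an exact number in this assay, at 6600 nM. From the compounds shown here alone, whether an amine or a carboxylic acid on the phenyl ring, or a longer chain in its place, would give a readable number remains open.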